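Vinyl in Place of Hydroxymethyl on a Shared Core

The source may report more compounds than this note shows. Statements on the series, on what has been measured and on what is new or still open speak of the compounds shown alone.

Compound 1 `COc1ccc([C@H]2NC(=O)O[C@H]2CO)cc1`: 26000 nM
Compound 2 `COc1ccc([C@H]2NC(=O)O[C@@H]2CO)cc1`: 56700 nM

In a functional assay on HeLa cells (Homo sapiens) for cytotoxicity (on this read-out higher numbers stand for weaker inhibition and lower numbers for stronger inhibition), compound 2 gives the highest of the two numbers. Among the compounds with values here, the only measured step, a 2.2-fold higher number from compound 1 to compound 2 (0.34 log units; beyond the scatter), comes from the fact that compounds 1 and 2 differ only in the configuration as drawn. Compound 3 `C=C[C@H]1OC(=O)N[C@@H]1c1ccc(OC)cc1` differs from compound 2 by vinyl in place of hydroxymethyl on a saturated ring carbon. Within the data shown here, no measured step involves a change of this kind, so the single stereochemical step gives no guide to its direction; no step beyond the scatter is expected either way. Compound 3 is therefore expected at 50000 nM, within 15000 nM to 180000 nM, which means an expected 1.1-fold lower number from compound 2 to compound 3 (0.05 log units; within the scatter).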

Compound 3, half-maximal inhibitory concentration: 39800 nM
Beside the measured number, compound 3's estimate is 1.3-fold (0.10 log units) above it; the measured number falls inside the stated range.
By their numbers in this assay, from the lowest: compounds 1, 3 and 2 (each within the scatter of the next, the first and the last beyond it).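

Vinyl in place of hydroxymethyl on this saturated ring carbon gives a 1.4-fold lower number from compound 2 to compound 3 (0.15 log units; within the scatter) in this assay and so does not shift the number beyond the usual scatter. At this position, then, the hydroxymethyl with its hydrogen-bond donor and acceptor can give way to vinyl, which has neither, with no clear change in this read-out. Nothing available accounts for this result. Still open, going by these compounds, is whether an amine, a carboxylic acid or a longer chain here would move the number, and how vinyl would fare with the configuration of compound 1.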